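The compounds below may be only part of what the source reports. "The series", "measured", "known", "first", "only" and "open" are said of these compounds alone.

Of the compounds shown here, three sharing one core have been measured in an ADME assay on the whole organism (Mus musculus, strain Swiss Webster) for pharmacokinetics, read by LC-MS, at a dose of 50 mg/kg by the oral route; a higher number here means more compound in the circulation at the dose given, a lower number less compound in the circulation. Compound 1 `O=C(Nc1ccc(F)c(-c2nc3ncc(-c4ccccc4F)cc3[nH]2)c1)N1CCCC1` gives 4870 ng.h/mL in this assay. Compound 2 `O=C(Nc1ccc(F)c(-c2nc3ncc(-c4cc(F)ccc4F)cc3[nH]2)c1)N1CCCC1` gives 5620 ng.h/mL, and compound 3 `O=C(Nc1ccc(F)c(-c2nc3ncc(-c4ccc(F)cc4F)cc3[nH]2)c1)N1CCCC1` gives 15600 ng.h/mL. Compound 2 therefore stands second highest of the three numbers: the step of a 1.2-fold higher number from compound 1 to compound 2 (0.06 log units; within the scatter) falls within the usual scatter, whereas the step of a 2.8-fold higher number from compound 2 to compound 3 (0.44 log units; beyond the scatter) lies beyond it. For completeness, the step of a 3.2-fold higher number from compound 1 to compound 3 (0.51 log units; beyond the scatter) is also beyond the scatter.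

The step under consideration leads to compound 4 `O=C(Nc1ccc(F)c(-c2nc3ncc(-c4ccc(F)cc4)cc3[nH]2)c1)N1CCCC1` through one change on the aryl group: 4-fluorophenyl in place of 2,5-difluorophenyl on an aromatic carbon.

Among the measured compounds shown here, two measured steps bear on this. Adding fluoro in place of hydrogen gave a 1.2-fold higher number from compound 1 to compound 2 (0.06 log units; within the scatter), so one fluoro more or fewer on that ring did not move the number beyond the scatter. Exchanging one difluorophenyl for another gave a 2.8-fold higher number from compound 2 to compound 3 (0.44 log units; beyond the scatter), a modest rise. Compound 4 both loses a fluoro and carries its remaining fluoro as 4-fluorophenyl, so the expected step of a 1.3-fold higher number from compound 2 to compound 4 (0.13 log units; within the scatter) is a small rise that may well sit within the scatter. Compound 4 is accordingly expected to give about 7500 ng.h/mL, with a likely range from 3500 ng.h/mL to 16000 ng.h/mL.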

Compound 4, area under the concentration-time curve: 10200 ng.h/mL
The estimate for compound 4 lay 1.4-fold (0.13 log units) below the measured number; low and high end bracket the measured number.
By their numbers in this assay, from the lowest: compounds 1, 2, 4 and 3 (each within the scatter of the next, the first and the last beyond it).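

The single fluoro turns out to matter by where it sits on the ring: in this assay, 4-fluorophenyl in place of 2-fluorophenyl gives a 2.1-fold higher number from compound 1 to compound 4 (0.32 log units; beyond the scatter), a modest step beyond the scatter. Losing a fluoro, by contrast, need not move the number beyond the scatter, as hydrogen in place of fluoro gives a 1.5-fold lower number from compound 3 to compound 4 (0.18 log units; within the scatter) and 4-fluorophenyl in place of 2,5-difluorophenyl gives a 1.8-fold higher number from compound 2 to compound 4 (0.26 log units; within the scatter), so compound 2 keeps the 4-fluorophenyl group from standing clearly apart from every other ring in the set. Adding one fluoro to a ring that already carries one stayed within the scatter in both cases, and the two steps agree with each other: the same change on two cores in this assay, a 1.2-fold higher number (0.06 log units; within the scatter) from compound 1 to compound 2 and a 1.5-fold higher number (0.18 log units; within the scatter) from compound 4 to compound 3, 1.3-fold (0.12 log units) apart, within the scatter of two such steps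

The compounds shown leave open how far the number depends on having any fluoro at all, which a plain phenyl ring would address, and how a chloro, a methoxy or an amine would read on this same ring. They also give one measure of exposure at one oral dose, so they cannot say which process in the animal lies behind these steps.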